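Chain-lengthened carbamate peptides and their plasma half-lives

The source may hold more compounds than are shown below. What is called first, only, known or untested is meant among the compounds shown, and "the series" means these compounds.

Measured so far in an ADME assay on a cell-free system (plasma, Homo sapiens) for metabolic stability, with Plasma (Rattus norvegicus) as the target; a higher number here means that the compound lasts longer, a lower number that the compound disappears faster:
compound 1 `C=COC(=O)[C@H](CC(C)C)NC(=O)[C@H](CC(C)C)NC(=O)[C@H](CC(C)C)NC(=O)CCNC(=O)OCc1ccccc1`, compound 1 gives > 6 h, a limit of the assay and not a number.
compound 2 `C=COC(=O)[C@H](CC(C)C)NC(=O)[C@H](CC(C)C)NC(=O)[C@H](CC(C)C)NC(=O)CCCNC(=O)OCc1ccccc1`, compound 2 gives > 6 h, again a limit and not a number.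
compound 3 `C=COC(=O)[C@H](CC(C)C)NC(=O)[C@H](CO)NC(=O)[C@@H](NC(=O)CCCCCCNC(=O)OCc1ccccc1)C(C)C`, compound 3 gives > 6 h, also a limit and not a number.

Compound 1 and compound 2 differ by ((benzyloxycarbonyl)amino)methyl in place of (benzyloxycarbonyl)amino on a saturated chain carbon, two bonds along the chain from a carbonyl carbon. Both readings are limits. The step that the two limits leave unreadable from compound 1 to compound 2 cannot be sized. All that can be said is given by the limit of > 6 h in this assay, at which 3 of the 3 values shown sit.

Compound 4 `C=COC(=O)[C@H](CC(C)C)NC(=O)[C@H](CO)NC(=O)[C@@H](NC(=O)CCCCCCCNC(=O)OCc1ccccc1)C(C)C` has not been measured. It differs from compound 3 by ((benzyloxycarbonyl)amino)methyl in place of (benzyloxycarbonyl)amino on a saturated chain carbon, six bonds along the chain from a carbonyl carbon. This is the same kind of change as from compound 1 to compound 2, but not the same: there it sat two bonds along the chain from a carbonyl carbon, here six bonds along the chain from a carbonyl carbon. How the core of compound 1 and the core of compound 3 differ is not broken down here.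

The expectation for compound 4 in this assay rests on compound 3 giving > 6 h and on the earlier lengthening, where compound 1 and compound 2 both sit at the limit shown by the limit of > 6 h in this assay, at which 3 of the 3 values shown sit. The step that the limit leaves unreadable from compound 3 to compound 4 is therefore expected to be small. Compound 4 is estimated at 9 h, between 5 h and 20 h, most likely again reported only as a limit.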

Compound 4, half-life: > 6 h
Compound 4: a limit, no number; the forecaster's own chance of this, stated with the estimate: 85%; the middle value does not contradict the limit.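

No new step can be read: compound 3 and compound 4 are both reported only as limits in this assay, so the lengthening between them cannot be sized. The compounds shown leave open how long each one actually lasts and whether chain length makes any difference to that, since every reading stops at the same limit: the limit of > 6 h in this assay, at which 4 of the 4 values shown sit.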